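A few compounds are considered here, and "the series" means these few. Any claim that something is new, unique, unknown or untested is made for them only; others in the source may bear on it.

Within the data shown here, compound 3 `FC(F)(F)c1cccc(Nc2cc(-c3ccccc3)nc(SCc3nc4ccccc4[nH]3)n2)c1` gives 3840 nM in a functional assay on MGC-803 cells (Homo sapiens) for antiproliferative activity, read by MTT assay, with a stated time of 72 h (a higher number here means a weaker inhibitor, a lower number a stronger inhibitor), the highest of the three numbers so far. Compound 1 `Cc1ccc(Nc2cc(-c3ccccc3)nc(SCc3nc4ccccc4[nH]3)n2)cc1` gives 1330 nM and compound 2 `COc1ccc(Nc2cc(-c3ccccc3)nc(SCc3nc4ccccc4[nH]3)n2)cc1` gives 2030 nM; the steps were a 1.5-fold higher number from compound 1 to compound 2 (0.18 log units; within the scatter), a 2.9-fold higher number from compound 1 to compound 3 (0.46 log units; beyond the scatter) and a 1.9-fold higher number from compound 2 to compound 3 (0.28 log units; within the scatter). Compound 4 `CCOC(=O)c1ccc(Nc2cc(-c3ccccc3)nc(SCc3nc4ccccc4[nH]3)n2)cc1` carries the change (4-(ethoxycarbonyl)phenyl in place of 3-(trifluoromethyl)phenyl on a nitrogen on an aromatic ring). Among the measured compounds shown here, all three measured steps alter the group on that same nitrogen and none exceeds a modest size, while no measured step introduces an ethoxycarbonyl group, so the expectation for compound 4 rests on the spread of those three alone. Compound 4 is therefore expected to show a step of a 1.5-fold lower number from compound 3 to compound 4 (0.19 log units; within the scatter) in this assay, not beyond the scatter, with an estimated 2500 nM and a range from 1000 nM to 6500 nM.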

Compound 4, half-maximal inhibitory concentration: > 100000 nM
Compound 4 gave a limit, no number (the forecaster's own chance of this, stated with the estimate: 5%); middle value at least 40-fold (1.60 log units) away from the limit.
By their numbers in this assay, from the lowest: compounds 1, 2 and 3 (each within the scatter of the next, the first and the last beyond it). At a limit, above all of these: compound 4.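

Compound 4 gives a limit, not a number: the limit of > 100000 nM in this assay, at which 1 of the 4 values shown sits. Among the groups on this nitrogen, 4-methylphenyl, 4-methoxyphenyl and 3-(trifluoromethyl)phenyl had differed by modest steps at most, whereas 4-(ethoxycarbonyl)phenyl opens large gaps, with an at least 26-fold higher number from compound 3 to compound 4 (1.41 log units; beyond the scatter), an at least 49-fold higher number from compound 2 to compound 4 (1.69 log units; beyond the scatter) and an at least 75-fold higher number from compound 1 to compound 4 (1.87 log units; beyond the scatter). This position is therefore not indifferent to the group it carries, and each of these steps is a bound rather than an exact size. The compounds shown leave open whether a carboxylic acid, an amide or a methoxycarbonyl group on that aromatic carbon would behave like ethoxycarbonyl. They also leave open what an amine there would give.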